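Swapping a thiophene for a pyridine on the enone chain

The source may hold more compounds than are shown below. What is called first, only, known or untested is meant among the compounds shown, and "the series" means these compounds.

Compound 1 `COc1ccc(/C=C/C(=O)c2ccc(OC)c3c2OC(C)(C)C=C3)c(F)c1`: 4880 nM
Compound 2 `COc1ccc(C(=O)/C=C/c2cccc([N+](=O)[O-])c2)c2c1C=CC(C)(C)O2`: 9720 nM
Compound 3 `COc1ccc(C(=O)/C=C/c2ccsc2)c2c1C=CC(C)(C)O2`: > 10000 nM (a limit of the assay, not a number)

Three compounds share the same core and differ only in the aromatic ring on a double-bonded chain carbon bound to a double-bonded chain carbon, and all were tested in a functional assay on SK-OV-3 cells (Homo sapiens) for antiproliferative activity, read by MTT assay, with a stated time of 24 h; on this read-out higher numbers stand for weaker inhibition and lower numbers for stronger inhibition. Compound 1 gives 4880 nM in this assay. Compound 2 gives 9720 nM in this assay, a step of a 2.0-fold higher number from compound 1 to compound 2 (0.30 log units; within the scatter). As far as these compounds go, for compound 3 the result in this assay is only a limit, > 10000 nM, so its true value is unknown beyond that. The step of an at least 2.0-fold higher number from compound 1 to compound 3 (0.31 log units; beyond the scatter) and the step of an at least 1.0-fold higher number from compound 2 to compound 3 (0.01 log units; that floor lies within the scatter) both end at this limit, as the note the limit of > 10000 nM in this assay, at which 1 of the 3 values shown sits, records.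

Compound 4 `COc1ccc(C(=O)/C=C/c2ccccn2)c2c1C=CC(C)(C)O2` is not yet measured. Its change from compound 3 is pyridin-2-yl in place of thiophen-3-yl on a double-bonded chain carbon bound to a double-bonded chain carbon. Going by the values given here, no measured step replaces a thiophene by a pyridine, so there is no direct guide; the only information is that compound 3 already sits at the limit, and the ring change is of similar scale to those seen. Compound 4 is therefore expected to remain near that limit, an estimated step of a number no higher from compound 3 to compound 4 (the limit leaves the size open), giving an estimated 10000 nM with a range from 3500 nM to 30000 nM in this assay.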

Compound 4, half-maximal inhibitory concentration: 8390 nM
Beside the measured number, compound 4's estimate is 1.2-fold (0.08 log units) above it; measured number inside the range.
By their numbers in this assay, from the lowest: compounds 1, 4 and 2 (each within the scatter of the next). At a limit, above all of these: compound 3.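

Putting pyridin-2-yl in place of thiophen-3-yl on a double-bonded chain carbon bound to a double-bonded chain carbon gives, in this assay, an at least 1.1-fold lower number from compound 3 to compound 4 (0.07 log units; that floor lies within the scatter), so this ring change has a measured end, but its size stays unsettled. Set against the two substituted phenyl rings, the new ring gives a 1.2-fold lower number from compound 2 to compound 4 (0.06 log units; within the scatter) and a 1.7-fold higher number from compound 1 to compound 4 (0.24 log units; within the scatter), and neither step separates it from those rings, so a six-membered ring with one nitrogen fits in this position about as well as they do. Compound 3 remains a limit of the assay, not a number: the limit of > 10000 nM in this assay, at which 1 of the 4 values shown sits.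

As far as these compounds go, how far compound 3 lies past its limit remains open, and with it the true size of the swap. Also open, from the compounds shown here alone, is what a phenyl ring carrying an amine or a carboxylic acid would give at this place.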